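A few compounds are considered here, and "the series" means these few. Any claim that something is new, unique, unknown or untested is made for them only; others in the source may bear on it.

Three compounds share one core and differ only in the group carried on an aromatic carbon. In a functional assay on NCI-H1299 cells (Homo sapiens) for inhibition, read by CCK-8 assay, with a stated time of 72 h, tested at 10 uM (a higher number here means a stronger effect of the compound at the concentration tested, a lower number a weaker effect), compound 1 `CN(C)C(=O)c1cc2cnc(Nc3ccc(S(=O)(=O)NCCCCCN=C=S)cc3)nc2n1C1CCCC1` gives 83.4%, compound 2 `CN(C)C(=O)c1cc2cnc(Nc3ccc(C(=O)NCCCN=C=S)cc3)nc2n1C1CCCC1` gives 91.2%, and compound 3 `CN(C)C(=O)c1cc2cnc(Nc3ccc(C(=O)NCCCCCCN=C=S)cc3)nc2n1C1CCCC1` gives 85%. Compound 3 thus stands second highest of the three numbers, with compound 1 nearest and compound 2 furthest, though both gaps lie within the scatter. Compound 4 `CN(C)C(=O)c1cc2cnc(Nc3ccc(NC(=O)CCCCCN=C=S)cc3)nc2n1C1CCCC1` has not yet been measured; it differs from compound 3 by a group of 11 heavy atoms (7 carbon, 2 nitrogen, 1 oxygen, 1 sulfur; no ring) in place of a group of 12 heavy atoms (8 carbon, 2 nitrogen, 1 oxygen, 1 sulfur; no ring), on an aromatic carbon. Within the data shown here, the steps that bear on this exchange are a number 1.6 percentage points higher from compound 1 to compound 3 (within the scatter) and a number 6.2 percentage points lower from compound 2 to compound 3 (within the scatter), and the step of a number 7.8 percentage points higher from compound 1 to compound 2 (within the scatter) behaves the same way: every change of this group seen so far has shifted the reading by less than the scatter. The step of no change at the digits printed from compound 3 to compound 4 (within the scatter) is therefore expected to remain within the scatter, in no particular direction. For compound 4 the estimate in this assay is 85%, with an expected range from 72% to 95%.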

Compound 4, a percentage reported as inhibition, at one concentration (the size of the read-out at that concentration, not a potency): 85%
Beside the measured number, compound 4's estimate shows no gap at the digits printed; measured number inside the range.
By their numbers in this assay, from the lowest: compounds 1, 3, 4 and 2 (each within the scatter of the next).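

In this assay, the exchange on an aromatic carbon, para to a large group, gives no change at the digits printed from compound 3 to compound 4 (within the scatter), and the other two new steps, a number 6.2 percentage points lower from compound 2 to compound 4 (within the scatter) and a number 1.6 percentage points higher from compound 1 to compound 4 (within the scatter), also stay within the scatter. Among these compounds, compound 4 is the first of the series whose group is joined to the aromatic ring through an amide nitrogen, rather than through the carbonyl of compounds 2 and 3 or the sulfonyl of compound 1, and this change of attachment leaves the reading within the scatter of all three. Nothing available explains this reading.

Every compound shown ends in an isothiocyanate, so the shown set leaves open how a chain ending in an amine or a carboxylic acid would read. With one concentration per compound, any difference in potency among these four also remains open.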